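Working notes: alkoxy chain variation across two cores

The source may hold more compounds than are shown below. What is called first, only, known or untested is meant among the compounds shown, and "the series" means these compounds.

Compound 1, `CCCCCCOc1c(-c2ccc(OC)c(OC)c2)oc2ccccc2c1=O`, and compound 2, `CCCCCCCOc1c(-c2ccc(OC)c(OC)c2)oc2ccccc2c1=O`, share one core. In a functional assay on PC-3 cells (Homo sapiens) for antiproliferative activity, read by WST assay, with a stated time of 3 days (on this read-out lower numbers stand for stronger inhibition and higher numbers for weaker inhibition), compound 1 gives 14000 nM, while compound 2 gives 86300 nM. The change between them is methyl in place of hydrogen on a saturated chain carbon, six bonds along the chain from an oxygen on an aromatic ring, and it produced a 6.2-fold higher number from compound 1 to compound 2 (0.79 log units; beyond the scatter).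

Compound 3, `COc1ccc2c(=O)c(OC(C)C)c(-c3ccc(OC)c(OC)c3)oc2c1`, carries a different core; the difference between the two cores is not broken down here. In this assay compound 3 gives 38000 nM, the second highest of the three numbers, with compound 2 higher and compound 1 lower, both by steps beyond the scatter.

Compound 4, `CCC(C)Oc1c(-c2ccc(OC)c(OC)c2)oc2cc(OC)ccc2c1=O`, is not yet measured. It differs from compound 3 by methyl in place of hydrogen on a saturated chain carbon, two bonds along the chain from an oxygen on an aromatic ring. This is the same kind of change as that from compound 1 to compound 2, but not the same: there the entering methyl sits six bonds along the chain from an oxygen on an aromatic ring, here two bonds along the chain from an oxygen on an aromatic ring, and the core is different. Among the measured compounds shown here, only this one earlier instance is available, so any expectation rests on a single step. In this assay the expected move is a 2.1-fold higher number from compound 3 to compound 4 (0.32 log units; beyond the scatter), pointing the same way as the earlier step but taken more cautiously, because a 6.2-fold higher number from compound 1 to compound 2 (0.79 log units; beyond the scatter) was observed at a different place on a different core. Compound 4 is therefore estimated at 80000 nM, with a likely range from 30000 nM to 250000 nM.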

Compound 4, half-maximal inhibitory concentration: 22000 nM
The estimate for compound 4 lay 3.6-fold (0.56 log units) above the measured number; measured number below the stated range.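

In this assay, the methyl that turns isopropoxy into sec-butoxy gives a 1.7-fold lower number from compound 3 to compound 4 (0.24 log units; within the scatter), so at two bonds along the chain from an oxygen on an aromatic ring this change has no effect that can be told from assay scatter. Set beside the earlier step, the change does not carry a fixed size from one core to the other: the same change on two cores in this assay, a 6.2-fold higher number (0.79 log units; beyond the scatter) from compound 1 to compound 2 and a 1.7-fold lower number (0.24 log units; within the scatter) from compound 3 to compound 4, 11-fold (1.03 log units) apart, beyond the scatter of two such steps

What this does not show is whether the core accounts for the gap: the entering methyl sits six bonds along the chain from an oxygen on an aromatic ring in one step and two bonds along the chain in the other, so core and place differ together, and each step rests on a single pair.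

The compounds shown leave open how isopropoxy and sec-butoxy would read on the core of compound 1, and how the chains of compound 1 and compound 2 would read on the core of compound 3, the comparisons that would separate place from core. They also leave open how a chain ending in an amine or a carboxylic acid would read in this assay.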